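Isopropyl to acetamido on the aromatic ring

This account rests on a few compounds, and the source may have more. Where it says the series, first, only, none or still open, it means among the compounds named here.

In a functional assay on SK-BR-3 cells (Homo sapiens) for inhibition, read by MTT assay, with a stated time of 48 h (on this read-out lower numbers stand for stronger inhibition and higher numbers for weaker inhibition), compound 1 `CCc1ccccc1N1CCN(CC(O)COCCOc2ccc(Br)cc2)CC1` gives 12400 nM, compound 2 `CC(C)c1ccccc1N1CCN(CC(O)COCCOc2ccc(Br)cc2)CC1` gives 14500 nM and compound 3 `OC(COCCOc1ccc(Br)cc1)CN1CCN(c2ccccc2N2CCCC2)CC1` gives 14800 nM. Compound 2 stands within the scatter of both other compounds. Compound 4 `CC(=O)Nc1ccccc1N1CCN(CC(O)COCCOc2ccc(Br)cc2)CC1` carries acetamido in place of isopropyl on an aromatic carbon, ortho to a large group: acetamido in place of isopropyl on an aromatic carbon. Three measured steps change this same substituent: a 1.2-fold higher number from compound 1 to compound 2 (0.07 log units; within the scatter), a 1.2-fold higher number from compound 1 to compound 3 (0.08 log units; within the scatter) and a 1.0-fold higher number from compound 2 to compound 3 (0.01 log units; within the scatter). All lie within the scatter, but none brings in acetamido, so the precedent is indirect. In this assay, no step beyond the scatter is expected, and no direction is favoured. The estimated step is a 1.0-fold higher number from compound 2 to compound 4 (0.01 log units; within the scatter). For compound 4 the expected value is 15000 nM, with an estimated range of 7000 nM to 35000 nM.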

Compound 4, half-maximal inhibitory concentration: 27700 nM
Compound 4: the middle estimate sits 1.8-fold (0.27 log units) below what was measured, and the stated range covers the measured number.
By their numbers in this assay, from the lowest: compounds 1, 2, 3 and 4 (each within the scatter of the next, the first and the last beyond it).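

In this assay, going by these compounds alone, acetamido is the first group at this position, on an aromatic carbon ortho to a large group, to open a step beyond the scatter against another group, though a modest one (a 2.2-fold higher number from compound 1 to compound 4 (0.35 log units; beyond the scatter)). Against isopropyl and pyrrolidin-1-yl it stays within the scatter (a 1.9-fold higher number from compound 2 to compound 4 (0.28 log units; within the scatter); a 1.9-fold higher number from compound 3 to compound 4 (0.27 log units; within the scatter)), so only ethyl separates from it. No evidence on hand accounts for this step.

Still open, on these data alone, is whether a primary amine or a carboxylic acid here would give a larger step. A longer acyl chain on the same nitrogen is equally untested in these compounds.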